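Swapping the bromine at the end of compound 3's chain

The compounds below may be only part of what the source reports. "The series", "measured", "known", "first", "only" and "open" are said of these compounds alone.

In a functional assay on A549 cells (Homo sapiens) for antiproliferative activity, read by MTT assay, with a stated time of 48 h (a higher number here means a weaker inhibitor, a lower number a stronger inhibitor), compound 1 (`COc1ccc(N(C)c2ccnc(Cl)n2)cc1`) gives 611 nM and compound 2 (`COc1ccc(N(C)c2ccnc(Cl)n2)cc1O`) gives 381 nM, and a 1.6-fold lower number from compound 1 to compound 2 (0.21 log units; within the scatter) is a small step. Compound 3 (`COc1ccc(N(C)c2ccnc(Cl)n2)cc1OCCBr`) gives 4640 nM, the highest number of the three, with a 7.6-fold higher number from compound 1 to compound 3 (0.88 log units; beyond the scatter) and a 12-fold higher number from compound 2 to compound 3 (1.09 log units; beyond the scatter). Compound 4 (`COc1ccc(N(C)c2ccnc(Cl)n2)cc1OCC[Se]C#N`) differs from it by a group of 3 heavy atoms (1 carbon, 1 nitrogen, 1 selenium; no ring) in place of one bromine atom, on a saturated chain carbon, two bonds along the chain from an oxygen on an aromatic ring, on a saturated chain carbon, two bonds along the chain from an oxygen on an aromatic ring. Among the measured compounds shown here, no measured step alters this chain end, but a 12-fold higher number from compound 2 to compound 3 (1.09 log units; beyond the scatter) shows that this side of the molecule can move the number considerably. A partial recovery is therefore expected in this assay, with an estimated 5.2-fold lower number from compound 3 to compound 4 (0.71 log units; beyond the scatter). The estimate for compound 4 is 900 nM, within a range of 200 nM to 4000 nM.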

Compound 4, half-maximal inhibitory concentration: 463 nM
Estimate against measurement, compound 4: 1.9-fold (0.29 log units) above, within the range that was stated.
By their numbers in this assay, from the lowest: compounds 2, 4 and 1 (each within the scatter of the next); then compound 3.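

In this assay the end of the chain proves to matter on its own: replacing the bromine with the group of selenium, carbon and nitrogen gives a 10-fold lower number from compound 3 to compound 4 (1.00 log units; beyond the scatter) with the chain length unchanged. The chain therefore need not weaken the compound, since the data show a 1.2-fold higher number from compound 2 to compound 4 (0.08 log units; within the scatter) and a 1.3-fold lower number from compound 1 to compound 4 (0.12 log units; within the scatter) and both steps lie within the scatter. No measurement here explains this swap. From the compounds shown here alone, whether the selenium or the nitrile carries the change remains open. So does how an amine at the chain end, or a longer chain, would behave.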